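Swapping Chloro for Methoxy: What One Earlier Step Suggests

A few compounds are considered here, and "the series" means these few. Any claim that something is new, unique, unknown or untested is made for them only; others in the source may bear on it.

Measured compounds:
Compound 1, `COc1ccc(/C=C/C(=O)c2ccc(NC(=S)Nc3ccc(Cl)cc3)cc2)cc1`: 10.4 umol/kg
Compound 2, `O=C(/C=C/c1ccc(Cl)cc1)c1ccc(NC(=S)Nc2ccc(Cl)cc2)cc1`: 7.59 umol/kg
Compound 3, `O=C(Nc1ccc(Cl)cc1)Nc1ccc(C(=O)/C=C/c2ccc(Cl)cc2)cc1`: 45.4 umol/kg

In a functional assay on the whole organism (Abdomen, strain Swiss) with Mus musculus as the target, with a stated time of 30 min (on this read-out higher numbers stand for an effect only at larger amounts of compound and lower numbers for an effect already at smaller amounts), compound 1 gives 10.4 umol/kg and compound 2 gives 7.59 umol/kg. Compound 3 gives 45.4 umol/kg in this assay, the highest of the three numbers, and its gap to each of the other two lies beyond the scatter. Compound 3 and compound 2 share much, but the difference between their two cores is not broken down here.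

Going from compound 2 to compound 1 means (methoxy in place of chloro on an aromatic carbon), and this gave a 1.4-fold higher number from compound 2 to compound 1 (0.14 log units; within the scatter). Compound 4, `COc1ccc(/C=C/C(=O)c2ccc(NC(=O)Nc3ccc(Cl)cc3)cc2)cc1`, carries the same change against compound 3: methoxy in place of chloro on an aromatic carbon. Because a 1.4-fold higher number from compound 2 to compound 1 (0.14 log units; within the scatter) stayed within the scatter, compound 4 is expected to sit close to compound 3, with an estimated step of a 1.2-fold higher number from compound 3 to compound 4 (0.08 log units; within the scatter) in this assay. Compound 4 is therefore estimated at 55 umol/kg, likely between 25 umol/kg and 130 umol/kg.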

Compound 4, dose for 50% inhibition: 31.1 umol/kg
For compound 4 the middle estimate is 1.8-fold (0.25 log units) above the measured one, and the stated range covers the measured number.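

Replacing 4-chlorophenyl with 4-methoxyphenyl on the second core gave a 1.5-fold lower number from compound 3 to compound 4 (0.16 log units; within the scatter) in this assay. On both cores, the same swap leaves the number within the usual scatter, and the two steps cannot be told apart: the same change on two cores in this assay, a 1.4-fold higher number (0.14 log units; within the scatter) from compound 2 to compound 1 and a 1.5-fold lower number (0.16 log units; within the scatter) from compound 3 to compound 4, 2.0-fold (0.30 log units) apart, within the scatter of two such steps This shows that, on these two cores, the swap carried over without a clear effect on the dose needed, but two pairs are too few to make a rule for other cores in the series.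

The compounds shown carry only chloro or methoxy at this place. They leave open whether a different group there, such as an amine or a carboxylic acid, would move the number beyond the scatter.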